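Methoxy for Nitro on the Benzylsulfanyl Arm

This account rests on a few compounds, and the source may have more. Where it says the series, first, only, none or still open, it means among the compounds named here.

Compound 2 `Cc1cc(N2CC[C@@H](C)[C@@H](N(C)c3ncnc4[nH]ccc34)C2)n2nc(SCc3ccc([N+](=O)[O-])cc3)nc2n1` gives 59600 nM in a functional assay on BGC-823 cells (Homo sapiens) for inhibition, read by MTT assay, with a stated time of 72 h (a lower number here means a stronger inhibitor, a higher number a weaker inhibitor), the higher of the two numbers shown, yet within the scatter of compound 1 `Cc1cc(N2CC[C@@H](C)[C@@H](N(C)c3ncnc4[nH]ccc34)C2)n2nc(SCC3CC3)nc2n1`, which gives 36500 nM. Among the compounds with values here, the only measured step, a 1.6-fold higher number from compound 1 to compound 2 (0.21 log units; within the scatter), stays within the scatter. Compound 3 `COc1ccc(CSc2nc3nc(C)cc(N4CC[C@@H](C)[C@@H](N(C)c5ncnc6[nH]ccc56)C4)n3n2)cc1` differs from compound 2 by methoxy in place of nitro on an aromatic carbon. Within the data shown here, no measured step touches this substituent itself, and the one step on this arm of the molecule was small, so no change beyond the scatter is expected in this assay. For compound 3 the expected value is 50000 nM, with a range of 20000 nM to 125000 nM. That amounts to an expected step of a 1.2-fold lower number from compound 2 to compound 3 (0.08 log units; within the scatter).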

Compound 3, half-maximal inhibitory concentration: 69900 nM
For compound 3 the middle estimate is 1.4-fold (0.15 log units) below the measured one, within the range that was stated.
By their numbers in this assay, from the lowest: compounds 1, 2 and 3 (each within the scatter of the next).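

In this assay methoxy in place of nitro on the aromatic carbon gives a 1.2-fold higher number from compound 2 to compound 3 (0.07 log units; within the scatter) and so shows no readable change at this position. On the same sulfur-bound arm, 4-methoxyphenyl in place of cyclopropyl gives a 1.9-fold higher number from compound 1 to compound 3 (0.28 log units; within the scatter) and also stays inside the scatter, so all three compounds read alike in this assay. Nothing measured here offers an explanation for this result.
On these data alone, whether an amine or a carboxylic acid on this aromatic carbon would move the number beyond the scatter remains open.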